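The source may report more compounds than this note shows. Statements on the series, on what has been measured and on what is new or still open speak of the compounds shown alone.

Of the compounds shown here, three sharing one core have been measured. Compound 1, `COc1cccc(-c2c(S(=O)(=O)c3ccc(C)c(F)c3)cnc3c(F)cccc23)c1`, gives 4.02 mL/min in an ADME assay on microsomes from liver (Homo sapiens) for metabolic stability, tested at 2.5 uM; on this read-out lower numbers stand for slow clearance and higher numbers for fast clearance. Compound 2, `Cc1ccc(S(=O)(=O)c2cnc3c(F)cccc3c2-c2ccc(Cl)cc2)cc1F`, gives 2.2 mL/min in this assay, and compound 3, `Cc1ccc(S(=O)(=O)c2cnc3c(F)cccc3c2-c2ccc(F)cc2)cc1F`, gives 2.75 mL/min in this assay. Of the three numbers, that of compound 3 is the second highest, though a 1.3-fold higher number from compound 2 to compound 3 (0.10 log units; within the scatter) and a 1.5-fold lower number from compound 1 to compound 3 (0.16 log units; within the scatter) both stay within the scatter, so no real ordering among these compounds can be claimed.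

Compound 4, `COc1ccc(-c2c(S(=O)(=O)c3ccc(C)c(F)c3)cnc3c(F)cccc23)cc1`, carries methoxy in place of fluoro on an aromatic carbon; cut one bond further out, the same difference reads 4-fluorophenyl to 4-methoxyphenyl. The measured steps that bear on it are a 1.5-fold lower number from compound 1 to compound 3 (0.16 log units; within the scatter), where a methoxy-bearing compound was compared with compound 3, and a 1.8-fold lower number from compound 1 to compound 2 (0.26 log units; within the scatter), which also swapped the group on this ring; neither left the scatter. Compound 1, which carries a methoxy group, gives 4.02 mL/min, so if anything a slightly higher number is expected. The expected step is a 1.3-fold higher number from compound 3 to compound 4 (0.10 log units; within the scatter), within the scatter. Compound 4 is estimated at 3.5 mL/min, with a range from 2 mL/min to 6 mL/min.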

Compound 4, intrinsic clearance in a liver preparation (reported as CLH), per the amount of preparation that the assay uses: 3.27 mL/min
Compound 4: middle estimate off by 1.1-fold (0.03 log units), on the high side; low and high end bracket the measured number.
By their numbers in this assay, from the lowest: compounds 2, 3, 4 and 1 (each within the scatter of the next).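

In this assay, methoxy at this position, para to a large group, gives a 1.2-fold higher number from compound 3 to compound 4 (0.08 log units; within the scatter) when it replaces fluoro, and a 1.5-fold higher number from compound 2 to compound 4 (0.17 log units; within the scatter) when it replaces chloro, so a direct swap to this larger group leaves the number within the usual spread of repeats. Taking 4-methoxyphenyl in place of 3-methoxyphenyl gives a 1.2-fold lower number from compound 1 to compound 4 (0.09 log units; within the scatter), the first comparison of the same group at two places on this ring, and that step also stays within the scatter. Fluoro, chloro and methoxy at this position therefore cannot be told apart on this read-out.

Going by these compounds, whether an amine, a carboxylic acid or a longer chain such as ethoxy here would move the number beyond the scatter stays open. Nothing available explains why these numbers sit so close together.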